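Ring Ether on a Methyl Link Replaces Methylcyclopentyl

The compounds below may be only part of what the source reports. "The series", "measured", "known", "first", "only" and "open" are said of these compounds alone.

compound 1 `Nc1ccc2cccc(OC3CCC3)c2n1` — > 2000 nM
compound 2 `CCC(C)COc1cccc2ccc(N)nc12` — 36 nM
compound 3 `CC1CCC(Oc2cccc3ccc(N)nc23)C1` — 823 nM

Three compounds share one core and differ only in the group on the oxygen on the aromatic ring. In an assay on cells with melanin-concentrating hormone receptor 1 (Homo sapiens) as the target, read by radioligand binding (a lower number here means a stronger inhibitor, a higher number a weaker inhibitor), compound 2 gives 36 nM. Compound 3 gives 823 nM in this assay. For compound 1 the reported value > 2000 nM is a limit of the assay and not a number (the limit of > 2000 nM in this assay, at which 1 of the 3 values shown sits).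

Among the two numbers given, compound 3 stands highest; its nearest neighbour is compound 2, and the gap is a 23-fold higher number from compound 2 to compound 3 (1.36 log units; beyond the scatter). Against compound 1 the step is an at least 2.4-fold lower number from compound 1 to compound 3 (0.38 log units; beyond the scatter). The largest step seen is an at least 55-fold lower number from compound 1 to compound 2 (1.74 log units; beyond the scatter).

Compound 4 `Nc1ccc2cccc(OCC3CCCO3)c2n1` has not yet been measured. It differs from compound 3 by (oxolan-2-yl)methyl in place of 3-methylcyclopentyl on an oxygen on an aromatic ring. Among the measured compounds shown here, the steps that bear on this are a 23-fold higher number from compound 2 to compound 3 (1.36 log units; beyond the scatter) and an at least 2.4-fold lower number from compound 1 to compound 3 (0.38 log units; beyond the scatter): compound 2 carries an open chain, compound 3 a ring set directly on the oxygen, and the (oxolan-2-yl)methyl group of compound 4 sets its ring on a methyl link, as in compound 2. Compound 4 is therefore expected to move toward a lower number, by a 4.1-fold lower number from compound 3 to compound 4 (0.61 log units; beyond the scatter). For compound 4 the estimate in this assay is 200 nM, ranging from 40 nM to 1500 nM.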

Compound 4, half-maximal inhibitory concentration: > 2000 nM
Compound 4: a limit, no number; the forecaster's own chance of this, stated with the estimate: 10%; middle value at least 10-fold (1.00 log units) away from the limit.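

In this assay compound 4 gives > 2000 nM, which is a limit of the assay and not a number. With the methyl link kept in place, oxolan-2-yl in place of sec-butyl gives an at least 55-fold higher number from compound 2 to compound 4 (1.74 log units; beyond the scatter), so among these compounds a methyl link alone does not go with the low number of compound 2. Swapping 3-methylcyclopentyl, set directly on the oxygen, for (oxolan-2-yl)methyl, which brings 1 hydrogen-bond acceptor and the same count of heavy atoms, gives an at least 2.4-fold higher number from compound 3 to compound 4 (0.38 log units; beyond the scatter), so this ring on a methyl link does not improve on the ring set directly on the oxygen.

The step between compound 1 and compound 4 cannot be read, because both compounds stand at the same limit: the limit of > 2000 nM in this assay, at which 2 of the 4 values shown sit.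

The compounds shown leave open whether the ring itself or the oxygen within it goes with the higher number, a question that cyclopentylmethyl, an all-carbon ring on the same link, would bear on directly.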